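Cytotoxicity of Three Analogues and a Fourth to Come

This account rests on a few compounds, and the source may have more. Where it says the series, first, only, none or still open, it means among the compounds named here.

Measured so far:
compound 1 `COc1cc(N2C(N)=C(C#N)C(c3ccc([N+](=O)[O-])cc3)C3=C2CC(C)(C)CC3=O)cc(OC)c1OC` gives 10% in a functional assay on Ehrlich cells (Mus musculus) for cytotoxicity, tested at 10 ug/mL; a higher number here means a stronger effect of the compound at the concentration tested, a lower number a weaker effect
compound 2 `COc1cc(N2C(N)=C(C#N)C(/C=C/c3ccccc3)C3=C2CC(C)(C)CC3=O)cc(OC)c1OC` gives 10% in this assay
compound 3 `COc1cc(N2C(N)=C(C#N)C(c3ccc(C)cc3)C3=C2CC(C)(C)CC3=O)cc(OC)c1OC` gives 30% in this assay

Compound 2 stands level with compound 1, and these two share the lowest number of the three, since no change at the digits printed from compound 1 to compound 2 (within the scatter). Compound 3 lies higher: a number 20 percentage points higher from compound 2 to compound 3 (beyond the scatter) and a number 20 percentage points higher from compound 1 to compound 3 (beyond the scatter), both modest steps.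

Compound 4 `COc1cc(N2C(N)=C(C#N)C(c3ccccc3Cl)C3=C2CC(C)(C)CC3=O)cc(OC)c1OC` has not yet been measured. It differs from compound 2 in one place: 2-chlorophenyl in place of 2-phenylethenyl on a saturated ring carbon.

Among the compounds with values here, two measured steps bear on this change. Both replace the group on that saturated ring carbon with an aromatic ring. From compound 1 to compound 2 the swap between 4-nitrophenyl and 2-phenylethenyl gave no step beyond the scatter, whereas a number 20 percentage points higher from compound 2 to compound 3 (beyond the scatter). An aromatic ring in that place thus gave either no change or a modest rise, so a step of similar size is expected here: a number 10 percentage points higher from compound 2 to compound 4 (within the scatter). Compound 4 is therefore estimated at 20%, with a likely range from 5% to 40%.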

Compound 4, a percentage reported as activity, at one concentration (the size of the read-out at that concentration, not a potency): 10%
The estimate for compound 4 lay 10 percentage points above the measured number; the range from low to high includes it.
By their numbers in this assay, from the lowest: compounds 1, 2 and 4 (each within the scatter of the next); then compound 3.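

With 2-chlorophenyl on the saturated ring carbon, the swap for 2-phenylethenyl gives no change at the digits printed from compound 2 to compound 4 (within the scatter) and the swap for 4-nitrophenyl gives no change at the digits printed from compound 1 to compound 4 (within the scatter), so a third group joins the low level in this assay. The swap for 4-methylphenyl gives a number 20 percentage points lower from compound 3 to compound 4 (beyond the scatter), which shows that a six-membered aromatic ring on this carbon does not by itself bring the higher number: among these four compounds, only compound 3 stands apart. No measurement shown here explains why these groups differ.

The compounds shown do not separate the effect of the chlorine from that of where it sits on the ring, since compound 3 and compound 4 differ in both. Going by these compounds, how plain phenyl, cyclohexyl or a longer alkyl chain would behave on this carbon also remains open.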